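The compounds below may be only part of what the source reports. "The series", "measured", "known", "first", "only" and "open" are said of these compounds alone.

Measured so far in a physicochemical assay for solubility; on this read-out higher numbers stand for higher solubility and lower numbers for lower solubility:
- compound 1 `CNC(=O)c1cc(C(=O)NC2CC2)c(C)n(Cc2ccccc2)c1=O`: >= 126 ug/mL
- compound 2 `CNC(=O)c1cc(C(=O)NC2CC2)cn(Cc2cccc([C@@H](C)O)c2)c1=O`: >= 131 ug/mL

Compound 1 gives >= 126 ug/mL, and this is a limit of the assay, not a number. Compound 2 gives >= 131 ug/mL, and this too is a limit of the assay, not a number. So compound 2 has no exact reading yet.

The next compound, compound 3 `CNC(=O)c1cc(C(=O)NC2CC2)cn(Cc2cccc3c2CCN3)c1=O`, changes one place in compound 2: 2,3-dihydro-1H-indol-4-yl in place of 3-(1-hydroxyethyl)phenyl on a saturated chain carbon bound to an aromatic nitrogen. In words, 2,3-dihydro-1H-indol-4-yl stands in place of 3-(1-hydroxyethyl)phenyl on a saturated chain carbon bound to an aromatic nitrogen.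

Among the compounds with values here, no measured step between two compounds is available to size this change, so the expectation in this assay is for no step beyond the scatter. The estimated change is an at least 1.1-fold lower number from compound 2 to compound 3 (0.07 log units; that floor lies within the scatter), which is expected to stay within that scatter. Compound 3 is estimated at 110 ug/mL, with an expected range of 50 ug/mL to 170 ug/mL.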

Compound 3, solubility: >= 184 ug/mL
Compound 3: only a limit was reported; the forecaster's own chance of this, stated with the estimate: 50%; at least 1.6-fold (0.22 log units) between middle value and limit.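

In this assay, compound 2 and compound 3 each give only a limit of the assay and not a number, so no step can be read between them. The compounds shown leave open the actual solubility of each one, and whether 2,3-dihydro-1H-indol-4-yl in place of 3-(1-hydroxyethyl)phenyl changes it at all.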